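The source may hold more compounds than are shown below. What is called first, only, known or untested is meant among the compounds shown, and "the series" means these compounds.

The series shares one core, carrying a substituted phenyl group on an amine nitrogen in a ring, and its members were tested in a functional assay on the whole organism (strain Swiss) with Mus musculus as the target, in the maximal electroshock model, with a stated time of 0.25 h, at a dose of 300 mg/kg by the intraperitoneal route; on this read-out lower numbers stand for a weaker effect and higher numbers for a stronger effect at the one dose given. Compound 1 `CCC(C(=O)N1CCN(c2ccc(F)cc2)CC1)N1C(=O)CCC1=O` gives 0% in this assay. Compound 2 `CCC(C(=O)N1CCN(c2ccccc2F)CC1)N1C(=O)CCC1=O` gives 100%. Compound 3 `CCC(C(=O)N1CCN(c2cccc(C(F)(F)F)c2)CC1)N1C(=O)CCC1=O` gives 75%, which places it second highest of the three measured numbers, below compound 2 and well above compound 1, both gaps lying beyond the usual scatter.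

Among the compounds with values here, the only measured step, a number 100 percentage points higher from compound 1 to compound 2 (beyond the scatter), moved a fluorine from one aromatic position to another and was large. It does not bear directly on the change now considered, which keeps the position and swaps the group.

Compound 4 `CCC(C(=O)N1CCN(c2cccc(Cl)c2)CC1)N1C(=O)CCC1=O` has not yet been measured. It differs from compound 3 by chloro in place of trifluoromethyl on an aromatic carbon. Within the data shown here, no measured pair shows a chloro in place of a trifluoromethyl, so there is no direct guide to the size or direction of this step. Among the measured compounds shown here, the single step known shows the read-out can swing widely with small changes on that ring, so a broad range is in order.

Compound 3 is therefore taken as the anchor, and for compound 4 the outcome is expected near it, with no change at the digits printed from compound 3 to compound 4 (within the scatter) as the estimated step. Compound 4 is estimated at 75%, within a range from 25% to 100%.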

Compound 4, a percentage reported as activity, at one dose (the size of the read-out at that dose, not a potency): 75%
Beside the measured number, compound 4's estimate shows no gap at the digits printed; measured number inside the range.
By their numbers in this assay, from the lowest: compound 1; then compounds 3 and 4 (each within the scatter of the next); then compound 2.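

Within the data shown here, measured in this assay the exchange of trifluoromethyl for chloro on an aromatic carbon, meta to a large group, gives no change at the digits printed from compound 3 to compound 4 (within the scatter) and so shows for the first time that this place keeps its read-out when a group of 4 heavy atoms gives way to one of 1 heavy atom. Compound 4 also links this place to the fluorinated compounds: 3-chlorophenyl in place of 2-fluorophenyl gives a number 25 percentage points lower from compound 2 to compound 4 (beyond the scatter) while 3-chlorophenyl in place of 4-fluorophenyl gives a number 75 percentage points higher from compound 1 to compound 4 (beyond the scatter) and thus two different groups at this place now share one level, short of compound 2 and far from compound 1. Nothing measured here offers a reason why the two groups read alike.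

As far as these compounds go, whether the same place would hold its read-out with a methoxy group, an amine or a carboxylic acid remains open, as does whether chloro on the other ring carbons would swing as widely as fluorine does in a number 100 percentage points higher from compound 1 to compound 2 (beyond the scatter) on that ring. A read-out at one dose also leaves open whether compound 3 and compound 4 would still match in potency.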